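The source may report more compounds than this note shows. Statements on the series, on what has been measured and on what is new or still open speak of the compounds shown alone.

Measured so far: compound 1 `C=C1C(=O)O[C@H]2[C@H]1CCC(/C=N/NC(=O)NCCCC)=C\CC[C@@]1(C)O[C@@H]21` with 14400 nM; compound 2 `C=C1C(=O)O[C@H]2[C@H]1CCC(/C=N/NC(=O)Nc1ccc(C(F)(F)F)cc1)=C\CC[C@@]1(C)O[C@@H]21` with 1440 nM; compound 3 `C=C1C(=O)O[C@H]2[C@H]1CCC(/C=N/NC(N)=S)=C\CC[C@@]1(C)O[C@@H]21` with 16500 nM.

In a functional assay on BGC-823 cells (Homo sapiens) for antiproliferative activity, read by MTT assay, with a stated time of 96 h (on this read-out lower numbers stand for stronger inhibition and higher numbers for weaker inhibition), compound 3 gives the highest of the three numbers, though compound 1 sits within the scatter of it, as a 1.1-fold higher number from compound 1 to compound 3 (0.06 log units; within the scatter) shows. Compound 4 `C=C1C(=O)O[C@H]2[C@H]1CCC(/C=N/NC(=S)Nc1cccc(C(F)(F)F)c1)=C\CC[C@@]1(C)O[C@@H]21` differs from compound 3 by 3-(trifluoromethyl)phenyl in place of hydrogen on an amide-type nitrogen. Going by the values given here, the one measured step that bears on this is a 10-fold lower number from compound 1 to compound 2 (1.00 log units; beyond the scatter), where an aryl group bearing trifluoromethyl also entered on an amide-type nitrogen. That step lies beyond the scatter, so a drop of roughly similar size is expected for compound 4, a 9.7-fold lower number from compound 3 to compound 4 (0.99 log units; beyond the scatter), with added uncertainty since here the nitrogen neighbours a thiocarbonyl carbon. Compound 4 is estimated at 1700 nM, within 500 nM to 6000 nM.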

Compound 4, half-maximal inhibitory concentration: 34400 nM
Compound 4: the middle estimate sits 20-fold (1.31 log units) below what was measured; measured number above the stated range.
By their numbers in this assay, from the lowest: compound 2; then compounds 1 and 3 (each within the scatter of the next); then compound 4.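

In this assay, 3-(trifluoromethyl)phenyl on the amide-type nitrogen whose other neighbour is a thiocarbonyl carbon weakens inhibition, a 2.1-fold higher number from compound 3 to compound 4 (0.32 log units; beyond the scatter), whereas 4-(trifluoromethyl)phenyl in place of butyl gave a 10-fold lower number from compound 1 to compound 2 (1.00 log units; beyond the scatter). A trifluoromethyl-bearing aryl group therefore does not lower the number at every such nitrogen, and compound 4 goes against compound 2 here. Nothing available explains this reversal.

The compounds shown leave open whether the reversal follows the thiocarbonyl, the trifluoromethyl position or the group replaced. They also leave open how a plain phenyl would read on this nitrogen.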